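The source may hold more compounds than are shown below. What is called first, only, known or untested is meant among the compounds shown, and "the series" means these compounds.

Compound 1 `CNc1ncnc2c1c(-c1ccoc1)cn2[C@@H]1O[C@H](CO)[C@@H](O)[C@H]1O`: > 20000 nM
Compound 2 `CNc1ncnc2c1c(-c1cc3ccccc3o1)cn2[C@@H]1O[C@H](CO)[C@@H](O)[C@H]1O`: > 20000 nM

In a functional assay on CEM-DNR-bulk cells (Homo sapiens), read by MTT assay, with a stated time of 72 h (a lower number here means a stronger inhibitor, a higher number a weaker inhibitor), compound 1 reaches only the limit of the assay, > 20000 nM. Compound 2 likewise gives only a limit, > 20000 nM. The step that the two limits leave unreadable from compound 1 to compound 2 therefore cannot be read as a number. On the numbers shown, compound 1 stands at the limit, as the limit of > 20000 nM in this assay, at which 2 of the 2 values shown sit, records, with no true value known for it.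

Compound 3 `CN(C)c1ncnc2c1c(-c1ccoc1)cn2[C@@H]1O[C@H](CO)[C@@H](O)[C@H]1O` differs from compound 1 by methyl in place of hydrogen on a nitrogen on an aromatic ring. Among the compounds with values here, no measured step bears directly on this change; the only measured step, a step that the two limits leave unreadable from compound 1 to compound 2, concerns another part of the molecule and is itself unreadable. With both shown values sitting at the limit, nothing here points to a shift in this assay beyond the scatter in either direction. Compound 3 is therefore expected to give 30000 nM in this assay, between 12000 nM and 100000 nM, most likely again only as a limit. The step that the limit leaves unreadable from compound 1 to compound 3 is estimated to stay small.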

Compound 3, half-maximal inhibitory concentration: > 20000 nM
Compound 3: a limit, no number; the forecaster's own chance of this, stated with the estimate: 85%; the middle value lies beyond the limit too.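

In this assay, within the data shown here, compound 3 again gives only a limit (> 20000 nM), not a number, so no step from compound 1 to compound 3 can be read. The compounds shown leave open how strong each truly is and whether the added methyl changes that: the limit of > 20000 nM in this assay, at which 3 of the 3 values shown sit.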